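Anilino Returns in Place of Azetidine: Activity Expected Back

The source may hold more compounds than are shown below. What is called first, only, known or untested is meant among the compounds shown, and "the series" means these compounds.

compound 1 `O=C1C(Nc2ccc(Br)cc2)=CC(=O)c2c1nc1n2[C@H]2OC[C@@H](O)[C@H]2OC1`: 2020 nM
compound 2 `O=C1C(N2CCC2)=CC(=O)c2c1nc1n2[C@H]2OC[C@@H](O)[C@H]2OC1`: > 16000 nM

In a functional assay on MGC-803 cells (Homo sapiens) for inhibition, read by sulforhodamine B assay (a higher number here means a weaker inhibitor, a lower number a stronger inhibitor), compound 1 gives 2020 nM. Compound 2 gives only > 16000 nM, which is a limit of the assay rather than a measured number (the limit of > 16000 nM in this assay, at which 1 of the 2 values shown sits). Compound 2 thus stands at the weak end of what has been measured. Compound 3 `O=C1C(Nc2cccc(Cl)c2)=CC(=O)c2c1nc1n2[C@H]2OC[C@@H](O)[C@H]2OC1` differs from compound 2 by (3-chlorophenyl)amino in place of azetidin-1-yl on a double-bonded ring carbon. Among the measured compounds shown here, the one measured step that bears on this is an at least 7.9-fold higher number from compound 1 to compound 2 (0.89 log units; beyond the scatter), where (4-bromophenyl)amino gave way to azetidin-1-yl. Compound 3 carries (3-chlorophenyl)amino, a group of the same kind, and a step back toward the value of compound 1 is expected, namely an at least 6.4-fold lower number from compound 2 to compound 3 (0.80 log units; beyond the scatter). The estimate for compound 3 is 2500 nM, between 800 nM and 8000 nM.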

Compound 3, half-maximal inhibitory concentration: 1530 nM
Beside the measured number, compound 3's estimate is 1.6-fold (0.21 log units) above it; measured number inside the range.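

Placing (3-chlorophenyl)amino on this double-bonded ring carbon gives, in this assay, an at least 10-fold lower number from compound 2 to compound 3 (1.01 log units; beyond the scatter). From the compounds shown here alone, the value for compound 2 is a limit and not a number, so the full size of that step stays unknown: the limit of > 16000 nM in this assay, at which 1 of the 3 values shown sits. The change of 4-bromophenyl to 3-chlorophenyl on the amine nitrogen gives a 1.3-fold lower number from compound 1 to compound 3 (0.12 log units; within the scatter), so these two substituted phenyl groups cannot be told apart here.

The compounds shown do not separate the part played by the aromatic ring from that of the amine hydrogen. Going by these compounds, how a benzylamino or dimethylamino group would read at this carbon also stays open.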